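Ortho-fluoro step on the benzylic aryl of sulfonamide series

A few compounds are considered here, and "the series" means these few. Any claim that something is new, unique, unknown or untested is made for them only; others in the source may bear on it.

Measured compounds:
- compound 1, `C[C@H](Nc1cc(F)c(S(=O)(=O)Nc2nccs2)cc1Cl)c1ccc(F)cc1`, gives 230 nM in an assay on HEK293 cells for inhibition of SCN8A/SCN1B (Homo sapiens), read by patch clamp, with a stated time of 20 min; a higher number here means a weaker inhibitor, a lower number a stronger inhibitor
- compound 2, `C[C@H](Nc1cc(F)c(S(=O)(=O)Nc2nccs2)cc1Cl)c1ccc(F)cc1F`, gives 40 nM in this assay
- compound 3, `C[C@H](Nc1cc(F)c(S(=O)(=O)Nc2cscn2)cc1Cl)c1ccccc1`, gives 650 nM in this assay

Compound 3 gives the highest number of the three in this assay; its gap to compound 2 is beyond the scatter. The difference between the core of compound 3 and that of compound 1 is not broken down here.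

One change recurs. From compound 1 to compound 2 it is fluoro in place of hydrogen on an aromatic carbon, and it gives a 5.8-fold lower number from compound 1 to compound 2 (0.76 log units; beyond the scatter). From compound 3 to compound 4, `C[C@H](Nc1cc(F)c(S(=O)(=O)Nc2cscn2)cc1Cl)c1ccccc1F`, the change is fluoro in place of hydrogen on an aromatic carbon. It is the same kind of change, not the same: in compound 1 the place is also meta to a fluoro group, in compound 3 it is not.

In this assay compound 4 is expected to show a 4.1-fold lower number from compound 3 to compound 4 (0.61 log units; beyond the scatter), somewhat smaller than the earlier step because the pair compound 1 to compound 2 carries a 5.8-fold lower number from compound 1 to compound 2 (0.76 log units; beyond the scatter) in a differently substituted ring. Compound 4 is estimated at 160 nM, between 70 nM and 350 nM.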

Compound 4, half-maximal inhibitory concentration: 410 nM
For compound 4 the middle estimate is 2.6-fold (0.41 log units) below the measured one, outside the stated range (above it).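

In this assay fluoro in place of hydrogen on an aromatic carbon gives a 1.6-fold lower number from compound 3 to compound 4 (0.20 log units; within the scatter), so on this core the change has no effect that can be told from repeat measurement. Set beside the earlier step, the same change does not carry over at the same size: the same change on two cores in this assay, a 5.8-fold lower number (0.76 log units; beyond the scatter) from compound 1 to compound 2 and a 1.6-fold lower number (0.20 log units; within the scatter) from compound 3 to compound 4, 3.6-fold (0.56 log units) apart, beyond the scatter of two such steps The gain on the core of compound 1 therefore cannot be taken as a fixed increment for this series, but two pairs do not show what sets the size of the step, whether the core itself or the further fluoro that compound 1 already carries on the ring taking the change.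

Open, on these data alone, is whether the gain on the core of compound 1 depends on that further fluoro, which a matched pair on the core of compound 3 carrying the same fluoro would test. Also open, as far as these compounds go, is how other groups, such as chloro, methyl or methoxy, behave in this place on either core.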